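Adding a methyl to a weak growth inhibitor

The source may report more compounds than this note shows. Statements on the series, on what has been measured and on what is new or still open speak of the compounds shown alone.

Compound 1 `Cc1ccc(COc2ccc(C(=O)/C=C/c3ccccc3)cc2)cc1` gives 43200 nM
Compound 2 `O=C(/C=C/c1ccc(F)cc1)c1ccc(OCc2ccccc2)cc1` gives > 50000 nM
Compound 3 `Cc1ccc(COc2ccc(C(=O)/C=C/c3ccc(F)cc3)cc2)cc1` is not yet measured

In a functional assay on CAL-51 cells (Homo sapiens) for inhibition, read by sulforhodamine B assay, with a stated time of 3 days (on this read-out higher numbers stand for weaker inhibition of growth and lower numbers for stronger inhibition of growth), compound 2 stands only at a limit (> 50000 nM) and has no exact number. Compound 3 differs from compound 2 by methyl in place of hydrogen on an aromatic carbon, para to a large group (methyl in place of hydrogen on an aromatic carbon). This change turns benzyl into 4-methylbenzyl. Compound 1 also carries 4-methylbenzyl and gives 43200 nM in this assay so a small step toward stronger inhibition is expected, possibly none beyond the scatter. The estimated step is an at least 1.1-fold lower number from compound 2 to compound 3 (0.07 log units; that floor lies within the scatter) and it stays uncertain. For compound 3 the expected value is 42000 nM with an estimated range from 18000 nM to 90000 nM in this assay here.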

Compound 3, concentration for 50% growth inhibition: > 50000 nM
Compound 3: no number, only a limit; the forecaster's own chance of this, stated with the estimate: 40%; middle value at least 1.1-fold (0.07 log units) from the limit.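

In this assay compound 3 gives > 50000 nM, which is a limit and not a number. Methyl in place of hydrogen on an aromatic carbon therefore brings no readable gain when fluoro is present, and the step between the two limits cannot be read. The pair carrying 4-methylbenzyl shows an at least 1.1-fold higher number from compound 1 to compound 3 (0.06 log units; that floor lies within the scatter).

On these data alone, whether the methyl changes growth inhibition at all stays open, and the values give little to compare: the limit of > 50000 nM in this assay, at which 2 of the 3 values shown sit. Also open is how an amine or a carboxylic acid in this place would read.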